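Adding a second methyl on the pyridinyl ether

A few compounds are considered here, and "the series" means these few. Any claim that something is new, unique, unknown or untested is made for them only; others in the source may bear on it.

For the measured compounds named here, compound 2 `Cc1cccnc1Oc1ccc2nc(COc3cccc(C(=O)O)c3)n(C)c2c1` gives 0.9 in a physicochemical assay for lipophilicity, read by LC-MS, in phosphate buffer, measured as octanol-water partition, with a stated time of 30 min, at pH 7.4, tested at 200 mM (on this read-out lower numbers stand for lower lipophilicity and higher numbers for higher lipophilicity), the lowest of the two numbers so far. Going by the values given here, compound 1 `Cn1c(COc2cccc(C(=O)O)c2)nc2ccc(Oc3cc(Cl)ccn3)cc21` gives 1.2, and the only measured step, a number 0.30 log units lower from compound 1 to compound 2 (within the scatter), is within the scatter. Compound 3 `Cc1ccc(Oc2ccc3nc(COc4cccc(C(=O)O)c4)n(C)c3c2)nc1C` carries 5,6-dimethylpyridin-2-yl in place of 3-methylpyridin-2-yl on an oxygen on an aromatic ring. Among the compounds with values here, no measured step adds a methyl without taking another group away, so the precedent is indirect. Compound 3 is expected to give 1.3, within 0.9 to 1.7, a modest rise of a number 0.40 log units higher from compound 2 to compound 3 (beyond the scatter), but the estimate is loosely founded.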

Compound 3, distribution coefficient: 1.3
The estimate for compound 3 equals the measured number at the digits printed; low and high end bracket the measured number.
By their numbers in this assay, from the lowest: compounds 2, 1 and 3 (each within the scatter of the next, the first and the last beyond it).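

In this assay, for the compounds shown here, the change on an oxygen on an aromatic ring now gives a step beyond the scatter: 5,6-dimethylpyridin-2-yl in place of 3-methylpyridin-2-yl gives a number 0.40 log units higher from compound 2 to compound 3 (beyond the scatter), the first such step at this position. Going by these compounds alone, in place of 4-chloropyridin-2-yl, the same group gives a number 0.10 log units higher from compound 1 to compound 3 (within the scatter), so only the pair with 3-methylpyridin-2-yl separates. Nothing available explains either step.

The compounds shown leave open which methyl of 5,6-dimethylpyridin-2-yl accounts for the step, and how an amine or a longer chain would read at this position.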